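The source may report more compounds than this note shows. Statements on the series, on what has been measured and on what is new or still open speak of the compounds shown alone.

Of the compounds shown here, two have so far been measured in an assay on U2OS cells for activation of nuclear factor erythroid 2-related factor 2 (Homo sapiens), read by chemiluminescence, with a stated time of 6 h; a lower number here means that less compound is needed, a higher number that more compound is needed for the effect. Compound 1 `COc1ccccc1S(=O)(=O)/C=C/c1cccnc1OC` gives only a limit there, > 10000 nM. Compound 2 `COc1ccccc1S(=O)(=O)/C=C/c1cccnc1Cl` gives 849 nM in this assay, the only number shown for any compound. The step of an at least 11-fold lower number from compound 1 to compound 2 (1.07 log units; beyond the scatter) tells how much that single change mattered, with the caveat that one end of it is the limit (the limit of > 10000 nM in this assay, at which 1 of the 2 values shown sits). Compound 3 `COc1ccccc1S(=O)(=O)/C=C/c1ccc(Cl)nc1Cl` differs from compound 2 in one place: chloro in place of hydrogen on an aromatic carbon. The one measured step concerns a chloro replacing a methoxy, not a hydrogen, so it bears on the new change only indirectly, and no comparison of a hydrogen with a chloro is available among these compounds. The expected step from compound 2 to compound 3, a 1.5-fold lower number from compound 2 to compound 3 (0.19 log units; within the scatter), is therefore modest, close to the scatter, with a slight lean toward a lower number. Compound 3 is estimated to give 550 nM, within a range from 150 nM to 2500 nM.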

Compound 3, half-maximal effective concentration: 178 nM
Estimate against measurement, compound 3: 3.1-fold (0.49 log units) above, within the range that was stated.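

In this assay, the hydrogen on this aromatic carbon, next to the ring nitrogen, can be replaced with a gain: there is a 4.8-fold lower number from compound 2 to compound 3 (0.68 log units; beyond the scatter), a change large enough to stand out from repeated-measurement noise. The earlier compounds shown here showed only what happens when a methoxy is swapped for a chloro at a different ring carbon, whereas this result concerns a carbon that held no group at all in compound 2. It also shows that a second chloro, placed meta to the first, still lowers the number, although the compounds shown offer no explanation for that effect:.

As far as these compounds go, it remains open whether this carbon favours chloro in particular or would also accept a fluoro, a methyl, a nitrile or an amine. The gain from this chloro might also differ if the neighbouring parts of the core were changed.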